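A few compounds are considered here, and "the series" means these few. Any claim that something is new, unique, unknown or untested is made for them only; others in the source may bear on it.

In an ADME assay on HEK293 cells (Homo sapiens) for cytotoxicity, read by reporter gene assay and resazurin assay, with a stated time of 48 h (on this read-out lower numbers stand for higher toxicity in this test and higher numbers for lower toxicity in this test), compound 2 `O=C(Nc1ccccc1)c1cccc(Br)c1` gives > 100000 nM, which is a limit of the assay and not a number. Compound 1 `O=C(Nc1ccccc1)c1cc(Br)ccc1O` gives 35000 nM in this assay. Among the compounds with values here, the one measured step bearing on the next change is an at least 2.8-fold higher number from compound 1 to compound 2 (0.45 log units; beyond the scatter), for hydrogen in place of hydroxy on an aromatic carbon. Compound 3 `COc1ccc(Br)cc1C(=O)Nc1ccccc1` departs from compound 2 at that same aromatic carbon, ortho to a group of 9 heavy atoms and para to a bromo group: methoxy in place of hydrogen on an aromatic carbon. Methoxy is not hydroxy, so the measured step, read in reverse, carries over only in part. A move from compound 2 towards lower numbers is expected, smaller than or similar to that step, and it may not rise beyond the scatter. The expected change is an at least 1.4-fold lower number from compound 2 to compound 3 (0.15 log units; that floor lies within the scatter). For compound 3 the estimate is 70000 nM, with an expected range of 25000 nM to 150000 nM.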

Compound 3, half-maximal cytotoxic concentration: > 100000 nM
Compound 3 ended at the assay's limit; the forecaster's own chance of this, stated with the estimate: 50%; middle value at least 1.4-fold (0.15 log units) away from the limit.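

In this assay, methyl in place of hydrogen on the oxygen gives an at least 2.8-fold higher number from compound 1 to compound 3 (0.45 log units; beyond the scatter), so masking the hydroxy group moves the number in the same direction as removing it. Among these compounds, the lower number of compound 1 therefore goes with hydroxy itself and not with just any oxygen on this aromatic carbon, ortho to a group of 9 heavy atoms and para to a bromo group. Compound 2 and compound 3 both stand at a limit of the assay and not at a number, and the step between them cannot be read because of this: the limit of > 100000 nM in this assay, at which 2 of the 3 values shown sit.

On these data alone, how far either compound lies past that limit stays open. So does whether an amine or a carboxylic acid on this aromatic carbon would track hydroxy or methoxy.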